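The source may report more compounds than this note shows. Statements on the series, on what has been measured and on what is new or still open speak of the compounds shown alone.

Measured compounds
- compound 1 `COc1c2cc(c(OC)c1O)Oc1ccc(cc1)[C@@H](O)C[C@@H](O)/C=C/C=C\2` — in a functional assay on U2OS cells (Homo sapiens) for cytotoxicity, read by spectrophotometry and crystal violet staining, with a stated time of 48 h (on this read-out higher numbers stand for an effect only at larger amounts of compound and lower numbers for an effect already at smaller amounts), compound 1 gives > 150000 nM, a limit of the assay.
- compound 2 `Oc1ccc2cc1-c1cc(ccc1O)C[C@H](O)[C@@H](O)[C@@H](O)C[C@@H](O)C2` — in this assay compound 2 gives > 150000 nM, also a limit.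
- compound 3 `O=C1CCc2ccc(O)c(c2)-c2cc(ccc2O)C[C@H](O)C[C@H]1O` — in this assay compound 3 gives > 150000 nM, again a limit.

Compound 3 stands where every measured member of the series stands: at the limit of > 150000 nM in this assay, at which 3 of the 3 values shown sit. Within the data shown here, no number is known for it, only the limit, so there is no ordering among compounds 1, 2 and 3 to draw on, and no measured step between any two of them.

The next compound, compound 4 `O=C1CCc2ccc(O)c(c2)-c2cc(ccc2O)C[C@H](O[C@@H]2O[C@H](CO)[C@H](O)[C@@H](O)[C@H]2O)C[C@H]1O`, differs from compound 3 in one place: a group of 11 heavy atoms (6 carbon, 5 oxygen; one six-membered non-aromatic ring with 1 hetero atom) in place of a hydrogen atom, on an oxygen on a saturated carbon. The change sits on an oxygen on a saturated carbon whose other neighbour is a saturated ring carbon; the rest of the core of compound 3 is kept.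

Among the measured compounds shown here, with no measured step, nothing indicates a shift in either direction in this assay, and no change beyond the usual scatter is expected. Compound 4 is therefore estimated at 200000 nM (range 100000 nM to 600000 nM), most likely reported again only as a limit; the step that the limit leaves unreadable from compound 3 to compound 4 is expected to be nil.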

Compound 4, half-maximal effective concentration: > 150000 nM
Compound 4: a limit, no number; the forecaster's own chance of this, stated with the estimate: 90%; the middle value lies beyond the limit too.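

No step can be read from compound 3 to compound 4, as neither has a number. In this assay compound 4 gives > 150000 nM, a limit. The compounds shown leave open whether any member of the series reaches a measurable value in this assay: the limit of > 150000 nM in this assay, at which 4 of the 4 values shown sit.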